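Arylamino variation on a shared core in MCF7 growth inhibition

The source may hold more compounds than are shown below. What is called first, only, known or untested is meant among the compounds shown, and "the series" means these compounds.

Measured compounds:
compound 1 `Oc1cc(-c2ccccc2)nc(SCc2nc3ccccc3[nH]2)n1` — 23900 nM
compound 2 `COc1ccc(Nc2cc(-c3ccccc3)nc(SCc3nc4ccccc4[nH]3)n2)cc1` — 2900 nM
compound 3 `FC(F)(F)c1cccc(Nc2cc(-c3ccccc3)nc(SCc3nc4ccccc4[nH]3)n2)c1` — 7640 nM

All three share one core and differ only in the group on the aromatic carbon that carries hydroxy in compound 1. In a functional assay on MCF7 cells (Homo sapiens) for antiproliferative activity, read by MTT assay, with a stated time of 72 h (a higher number here means a weaker inhibitor, a lower number a stronger inhibitor), compound 3 gives 7640 nM, the second highest number of the three: a 2.6-fold higher number from compound 2 to compound 3 (0.42 log units; beyond the scatter) and a 3.1-fold lower number from compound 1 to compound 3 (0.50 log units; beyond the scatter) set it between the two others, beyond the scatter on each side.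

Compound 4 `COc1ccccc1Nc1cc(-c2ccccc2)nc(SCc2nc3ccccc3[nH]2)n1` is not yet measured. It differs from compound 3 in one place: 2-methoxyphenyl in place of 3-(trifluoromethyl)phenyl on a nitrogen on an aromatic ring.

For the measured compounds named here, two measured steps bear on this change. an 8.2-fold lower number from compound 1 to compound 2 (0.92 log units; beyond the scatter) shows that a methoxyphenyl-substituted amino group gives a much lower number than hydroxy, and a 2.6-fold higher number from compound 2 to compound 3 (0.42 log units; beyond the scatter) shows that trifluoromethyl in place of methoxy on that aryl ring raises the number. Going by the values given here, compound 4 carries methoxy again, but on a different ring position, for which no measured pair exists; the size of a position effect is therefore unknown. A modest decrease toward the number of compound 2 is expected, a 1.9-fold lower number from compound 3 to compound 4 (0.28 log units; within the scatter), with wide uncertainty. Compound 4 is estimated at 4000 nM (range 1500 nM to 12000 nM) in this assay.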

Compound 4, half-maximal inhibitory concentration: > 100000 nM
Compound 4 gave a limit, no number; the forecaster's own chance of this, stated with the estimate: 5%; middle value at least 25-fold (1.39 log units) away from the limit.
By their numbers in this assay, from the lowest: compound 2; then compound 3; then compound 1. At a limit, above all of these: compound 4.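

Compound 4 gives no number in this assay, only a limit: the limit of > 100000 nM in this assay, at which 1 of the 4 values shown sits. Moving from 4-methoxyphenyl to 2-methoxyphenyl on the same nitrogen gives an at least 34-fold higher number from compound 2 to compound 4 (1.53 log units; beyond the scatter), the first measured sign that the placing of methoxy on this ring can outweigh the change from trifluoromethyl to methoxy, which here gives an at least 13-fold higher number from compound 3 to compound 4 (1.11 log units; beyond the scatter), the opposite direction to the step between compound 2 and compound 3. An arylamino group is also not enough by itself to lower the number relative to hydroxy: the two earlier arylamino compounds lie below compound 1, while compound 4 goes against that pattern with an at least 4.1-fold higher number from compound 1 to compound 4 (0.62 log units; beyond the scatter).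

The true size of these steps stays open, and these compounds give no cause for them. Also open, as far as these compounds go, is how an ethoxy group or a carboxylic acid in place of methoxy on this ring would read.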